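Dichlorophenyl in place of trifluoromethylphenyl on the amide nitrogen

The source may hold more compounds than are shown below. What is called first, only, known or untested is meant among the compounds shown, and "the series" means these compounds.

Measured compounds:
Compound 1, `COc1cc(-c2nn(-c3cccc(NC(=O)c4ccc(Cl)c(C(F)(F)F)c4)c3)cc2-c2ccncc2)ccc1Cl`, sits at the limit > 32500 nM in a functional assay on MDA-MB-468 cells (Homo sapiens) for inhibition, read by sulforhodamine B assay, with a stated time of 48 h; a lower number here means that less compound is tolerated, a higher number that more compound is tolerated.
Compound 2, `COc1cc(-c2nn(-c3cccc(NC(=O)Nc4cccc(C(F)(F)F)c4)c3)cc2-c2ccncc2)ccc1Cl`, gives 50000 nM in this assay.
Compound 3, `O=C(Nc1cccc(-n2cc(-c3ccncc3)c(-c3ccc(Cl)c(O)c3)n2)c1)Nc1cccc(C(F)(F)F)c1`, sits at the limit > 32500 nM in this assay.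

Within the data shown here, compound 2 is the only compound of the three with a number in this assay; the entries for compound 1 and compound 3 are limits of the assay, as the limit of > 32500 nM in this assay, at which 2 of the 3 values shown sit, records. The two steps joining the measured compounds, a step that the limit leaves unreadable from compound 1 to compound 2 and a step that the limit leaves unreadable from compound 2 to compound 3, are for that reason unreadable in size, and neither touches the place that changes here.

Compound 4, `COc1cc(-c2nn(-c3cccc(NC(=O)Nc4ccc(Cl)c(Cl)c4)c3)cc2-c2ccncc2)ccc1Cl`, differs from compound 2 at the amide-type nitrogen: 3,4-dichlorophenyl in place of 3-(trifluoromethyl)phenyl on an amide-type nitrogen. Among the measured compounds shown here, no measured step bears on this change directly. The nearest comparison, from compound 1 to compound 2, alters the group on the carbonyl carbon side and is itself unreadable. With nothing readable to lean on, the expectation for compound 4 is no step beyond the scatter; no change at the digits printed from compound 2 to compound 4 (within the scatter) is the step the estimate assumes. Compound 4 is therefore estimated at 50000 nM, between 20000 nM and 120000 nM, with a real chance that the assay reports only a limit.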

Compound 4, concentration lethal to 50% of the cells: > 50000 nM
Compound 4: only a limit was reported; the forecaster's own chance of this, stated with the estimate: 50%; the middle value sits exactly at the limit.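

Replacing 3-(trifluoromethyl)phenyl with 3,4-dichlorophenyl on an amide-type nitrogen gives a number no lower from compound 2 to compound 4 (the limit leaves the size open) in this assay. Among these compounds, this is the first comparison at this place, and it shows that this change brings no lowering of the number, though how far the number rises stays unknown. The entry for compound 4 is a limit of the assay and not a number: the limit of > 50000 nM in this assay, at which 1 of the 4 values shown sits.

Among the compounds shown here, the comparison of compound 1 with compound 4 joins two limits and cannot be read, so only the pair of compound 2 and compound 4 speaks to this change, and no general pattern follows from it. As far as these compounds go, what stays open is how large the step at this nitrogen really is, and whether an aryl group carrying an amine or a carboxylic acid in place of the two chlorines would give a readable value in this assay.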